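Trifluoromethoxy for fluoro on a pyrimidinedione piperidine

The source may report more compounds than this note shows. Statements on the series, on what has been measured and on what is new or still open speak of the compounds shown alone.

Measured compounds:
compound 1 `Cc1cn(C2CCN(Cc3cccc(Oc4cccc(F)c4)c3)CC2)c(=O)[nH]c1=O`: > 64000 nM
compound 2 `Cc1cn(C2CCN(Cc3cccc(Oc4cc(C(F)(F)F)cc(C(F)(F)F)c4)c3)CC2)c(=O)[nH]c1=O`: "not determined" (no result reported)
compound 3 `Cc1cn(C2CCN(Cc3cc(Oc4ccccc4)ccn3)CC2)c(=O)[nH]c1=O`: > 64000 nM

Three compounds sharing one core were tested in an ADME assay on MRC5 cells (Homo sapiens) for cytotoxicity, read by fluorescence and resazurin assay, with a stated time of 3 days; on this read-out higher numbers stand for weaker inhibition and lower numbers for stronger inhibition. Compound 1 gives > 64000 nM; this is a limit of the assay, not a number. Compound 3 likewise gives > 64000 nM, again a limit rather than a number. For compound 2 the assay gives "not determined" (no result reported), so no result was reported. So compound 1 stands at the limit of > 64000 nM in this assay, at which 2 of the 3 values shown sit, and nothing here separates it from compound 3, which sits at the same limit.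

The unmeasured compound 4 `Cc1cn(C2CCN(Cc3cccc(Oc4cccc(OC(F)(F)F)c4)c3)CC2)c(=O)[nH]c1=O` differs from compound 1 in one place: trifluoromethoxy in place of fluoro on an aromatic carbon. Among the measured compounds shown here, no step between two measured compounds is available to say how a change of this kind shifts the read-out.

Because compound 1 gives only the limit (the limit of > 64000 nM in this assay, at which 2 of the 3 values shown sit), compound 4 is expected to give 80000 nM, most likely as a limit again, with a range from 30000 nM to 250000 nM. The step from compound 1 to compound 4 is thus expected to be none beyond the scatter, a step that the limit leaves unreadable from compound 1 to compound 4.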

Compound 4, half-maximal inhibitory concentration: 5260 nM
For compound 4 the middle estimate is 15-fold (1.18 log units) above the measured one, and the stated range ends above it.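

In this assay, among the compounds shown here, the earlier compounds gave no actual number, so they could not show whether a change on this ring moves the read-out at all. Going from 3-fluorophenyl to 3-(trifluoromethoxy)phenyl gives an at least 12-fold lower number from compound 1 to compound 4 (1.08 log units; beyond the scatter), so this place, on a six-membered aromatic ring of carbon only and meta to a large group, is not indifferent: one change there is enough to bring a measurable effect on the cells into view. The step is a minimum and its true size cannot be read, because its starting point is a limit of the assay and not a number: the limit of > 64000 nM in this assay, at which 2 of the 4 values shown sit.

Which feature of trifluoromethoxy lies behind the step stays open: a single pair of compounds cannot tell. Also open, from the compounds shown here alone, is where a methoxy group, a chlorine atom or an amine at the same place would fall, and so whether the effect belongs to trifluoromethoxy alone or to a wider range of groups there.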